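The compounds below may be only part of what the source reports. "The series", "measured", "known", "first", "only" and "open" are said of these compounds alone.

Measured so far in a functional assay on BaF3 cells (Mus musculus) for antiproliferative activity, with a stated time of 48 h; a lower number here means a stronger inhibitor, a higher number a weaker inhibitor:
- compound 1 `CC(=O)N1CCN([C@H]2C[C@@H](n3cc(-c4ccc(Cl)c(N)c4)c4c(N)ncnc43)C2)CC1`: 4600 nM
- compound 2 `CC(=O)N1CCN([C@H]2C[C@@H](n3cc(-c4cc(O)ccc4F)c4c(N)ncnc43)C2)CC1`: > 10000 nM (a limit, not a number)

Compound 2 has no number in this assay, only a limit: the limit of > 10000 nM in this assay, at which 1 of the 2 values shown sits. Going by the values given here, the single measured step is an at least 2.1-fold higher number from compound 1 to compound 2 (0.33 log units; beyond the scatter). That step exchanges 3-amino-4-chlorophenyl for 2-fluoro-5-hydroxyphenyl, so two whole substituted groups differ at once, and it does not isolate any one atom.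

Compound 3 `CC(=O)N1CCN([C@H]2C[C@@H](n3cc(-c4cccc(O)c4)c4c(N)ncnc43)C2)CC1` differs from compound 2 in one place: hydrogen in place of fluoro on an aromatic carbon. The 2-fluoro-5-hydroxyphenyl group becomes 3-hydroxyphenyl, with hydrogen in place of fluoro on an aromatic carbon. Among the compounds with values here, no measured pair shows this exchange on its own, so the size of its effect cannot be read from the data.

Since compound 2 sits at > 10000 nM, which is a limit, compound 3 is expected to remain a weak inhibitor in this assay. The estimate is a number no higher from compound 2 to compound 3 (the limit leaves the size open), and no clear direction is expected for this change. For compound 3 the estimated value is 10000 nM, with an expected range from 3500 nM to 30000 nM.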

Compound 3, half-maximal inhibitory concentration: > 10000 nM
Compound 3: a limit, no number; the forecaster's own chance of this, stated with the estimate: 50%; the middle value sits exactly at the limit.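

Taking the fluoro away does not bring a measurable value back in this assay: compound 3 gives > 10000 nM, which is a limit and not a number. The 3-hydroxyphenyl group, set against the 3-amino-4-chlorophenyl group, gives an at least 2.1-fold higher number from compound 1 to compound 3 (0.33 log units; beyond the scatter), so the higher number seen with 2-fluoro-5-hydroxyphenyl does not depend on the fluoro being present. The size of the fluoro-to-hydrogen step itself cannot be read, and compound 2 and compound 3 cannot be ranked against each other, as the values now gather at one point: the limit of > 10000 nM in this assay, at which 2 of the 3 values shown sit.

The compounds shown leave open whether the amino group or the chloro group of compound 1 carries its measurable value, as the two occur only together here. A phenyl ring bearing the amino group alone or the chloro group alone would separate the two, and would show which of them matters more in this assay.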